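Methyl in place of benzyl on selenium, with nitro groups present

A few compounds are considered here, and "the series" means these few. Any claim that something is new, unique, unknown or untested is made for them only; others in the source may bear on it.

Compounds 1 and 2 share a core built from two thiophene-carbonyl amide arms around an isoselenourea; compound 1 `C[Se]/C(=N\C(=O)c1cccs1)NC(=O)c1cccs1` carries a methyl group on the selenium atom, compound 2 `O=C(/N=C(/NC(=O)c1cccs1)[Se]Cc1ccccc1)c1cccs1` a benzyl group. In a functional assay on K562 cells (Homo sapiens) for cytotoxicity, read by MTT assay, with a stated time of 72 h (a higher number here means a weaker inhibitor of growth, a lower number a stronger inhibitor of growth), compound 2 gives 58500 nM. For compound 1 the result is a limit of the assay rather than a number, > 100000 nM, and it is the limit of > 100000 nM in this assay, at which 1 of the 3 values shown sits. The change hydrogen in place of phenyl on a saturated chain carbon bound to a selenium atom thus made an at least 1.7-fold higher number from compound 2 to compound 1 (0.23 log units; that floor lies within the scatter).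

Compound 3 `O=C(/N=C(/NC(=O)c1csc([N+](=O)[O-])c1)[Se]Cc1ccccc1)c1csc([N+](=O)[O-])c1` carries the benzyl group of compound 2 but has a nitro group on each thiophene ring; the difference between the two cores is not broken down here. In this assay compound 3 gives 55800 nM, and its number and that of compound 2 lie within the scatter of each other.

Compound 4 `C[Se]/C(=N\C(=O)c1csc([N+](=O)[O-])c1)NC(=O)c1csc([N+](=O)[O-])c1` is compound 3 with the change (hydrogen in place of phenyl on a saturated chain carbon bound to a selenium atom), the same change that led from compound 2 to compound 1. The step expected here is a 2.2-fold higher number from compound 3 to compound 4 (0.33 log units; beyond the scatter), because the same change earlier gave an at least 1.7-fold higher number from compound 2 to compound 1 (0.23 log units; that floor lies within the scatter). Compound 4 is therefore estimated at 120000 nM, with a range from 50000 nM to 300000 nM, and the assay may well report only a limit.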

Compound 4, concentration for total growth inhibition: > 100000 nM
Compound 4 gave a limit, no number (the forecaster's own chance of this, stated with the estimate: 70%); the middle value lies beyond the limit too.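

In this assay, benzyl to methyl on the selenium gives an at least 1.7-fold higher number from compound 3 to compound 4 (0.25 log units; that floor lies within the scatter). Carried to the core with nitro groups, the change again leaves a methyl compound with a limit of the assay rather than a number, and neither step points toward a lower number: the same change on two cores in this assay, an at least 1.7-fold higher number (0.23 log units; that floor lies within the scatter) from compound 2 to compound 1 and an at least 1.7-fold higher number (0.25 log units; that floor lies within the scatter) from compound 3 to compound 4; the limit leaves it open whether they differ. This does not give the true size of either step, and with each floor inside the scatter, it does not prove that methyl gives a higher number than benzyl on either core: the limit of > 100000 nM in this assay, at which 2 of the 4 values shown sit.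

Only benzyl and methyl appear on the selenium here, and an ethyl group, a longer chain or an amine at the end of such a chain could give a number anywhere relative to them. As far as these compounds go, it also stays open whether any group on the selenium could bring the number well below those of compound 2 and compound 3.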